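A few compounds are considered here, and "the series" means these few. Any claim that something is new, unique, unknown or untested is made for them only; others in the source may bear on it.

Compound 1: `Oc1ccc(-c2cc(-c3ccccc3O)cc(-c3cccc(O)c3)n2)cc1`; in a functional assay on T47D cells (Homo sapiens) for cytotoxicity, read by CCK-8 assay, with a stated time of 4 days (a lower number here means a stronger inhibitor, a higher number a weaker inhibitor), compound 1 gives 650 nM.
Compound 2: `Oc1cccc(-c2cc(-c3cccc(O)c3)nc(-c3ccccc3O)c2)c1`; in this assay compound 2 gives 50000 nM.
Compound 3: `Oc1cccc(-c2cc(-c3ccccc3O)cc(-c3cccc(O)c3)n2)c1`; in this assay compound 3 gives 4570 nM.

Among these three numbers compound 3 stands second highest. For the measured compounds named here, its closest neighbour is compound 1, and the single-point step between them, a 7.0-fold higher number from compound 1 to compound 3 (0.85 log units; beyond the scatter), is the only one that changes just one group. Compound 2 carries the same three groups as compound 3 joined differently, and its number is the highest of the three.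

Compound 4, `Oc1cccc(-c2cc(-c3ccccc3O)cc(-c3ccccc3O)n2)c1`, is reached from compound 3 by 2-hydroxyphenyl in place of 3-hydroxyphenyl on an aromatic carbon. Going by the values given here, no measured step exchanges a 3-hydroxyphenyl for a 2-hydroxyphenyl, so the direction is open; the one step at this position, a 7.0-fold higher number from compound 1 to compound 3 (0.85 log units; beyond the scatter), shows that moving the hydroxyl around the ring can shift the number beyond the scatter, but it tells nothing about the 2-hydroxyphenyl itself. The expected step is therefore a 1.3-fold higher number from compound 3 to compound 4 (0.12 log units; within the scatter), with wide uncertainty. Compound 4 is estimated at 6000 nM, within a range from 1500 nM to 30000 nM.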

Compound 4, half-maximal inhibitory concentration: 5760 nM
Compound 4: middle estimate off by 1.0-fold (0.02 log units), on the high side; the measured number falls inside the stated range.
By their numbers in this assay, from the lowest: compound 1; then compounds 3 and 4 (each within the scatter of the next); then compound 2.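

At the place next to the ring nitrogen, in this assay the exchange gives a 1.3-fold higher number from compound 3 to compound 4 (0.10 log units; within the scatter) and so does not separate the 2-hydroxyphenyl from the 3-hydroxyphenyl, while the 4-hydroxyphenyl of compound 1 stands apart from both, with an 8.9-fold higher number from compound 1 to compound 4 (0.95 log units; beyond the scatter) as well as the earlier 7.0-fold higher number from compound 1 to compound 3 (0.85 log units; beyond the scatter). The same exchange of groups at another place on the shared core is not silent, giving an 8.7-fold lower number from compound 2 to compound 4 (0.94 log units; beyond the scatter), so the size of this change depends on where on the core it is made. Nothing measured here explains these differences.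

From the compounds shown here alone, it remains open what a methoxy group or an amine would do in place of the hydroxyl on this ring. A plain phenyl at this position would show whether a hydroxyl is needed there at all.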